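The compounds below may be only part of what the source reports. "The series", "measured", "known", "first", "only" and "open" are said of these compounds alone.

Measured so far:
- Compound 1 `CC(=O)Oc1ccc2oc(/C=C/[S+](C)[O-])cc(=O)c2c1`: in a functional assay on DLD-1 cells (Homo sapiens) for cytotoxicity, with a stated time of 48 h (a lower number here means a stronger inhibitor, a higher number a weaker inhibitor), compound 1 gives > 10000 nM, which is a limit of the assay rather than a number.
- Compound 2 `C[S+]([O-])/C=C/c1cc(=O)c2cc(O)ccc2o1`: in this assay compound 2 gives > 10000 nM, again a limit.
- Compound 3 `C[S+]([O-])/C=C/c1cc(=O)c2cc(F)ccc2o1`: in this assay compound 3 gives 7000 nM.

Among the compounds with values here, compound 3 thus holds the only real number among the three, while the other two sit at the limit (the limit of > 10000 nM in this assay, at which 2 of the 3 values shown sit). The next compound, compound 4 `C[S+]([O-])/C=C/c1cc(=O)c2cc(Br)ccc2o1`, differs from compound 3 by bromo in place of fluoro on an aromatic carbon. Within the data shown here, the steps that touch this position are an at least 1.4-fold lower number from compound 1 to compound 3 (0.15 log units; that floor lies within the scatter) and an at least 1.4-fold lower number from compound 2 to compound 3 (0.15 log units; that floor lies within the scatter), both floors that lie within the scatter; neither involves a bromo, so no measured step shows what this swap does. A step in this assay no larger than the scatter is therefore expected, a 1.4-fold lower number from compound 3 to compound 4 (0.15 log units; within the scatter). Compound 4 is estimated at 5000 nM, between 1500 nM and 15000 nM.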

Compound 4, half-maximal inhibitory concentration: 4500 nM
For compound 4 the middle estimate is 1.1-fold (0.05 log units) above the measured one; the range from low to high includes it.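

On this aromatic carbon, bromo and fluoro cannot be told apart in this assay, with a 1.6-fold lower number from compound 3 to compound 4 (0.19 log units; within the scatter). Bromo is the first group here to clear the scatter against hydroxy and acetoxy, with an at least 2.2-fold lower number from compound 2 to compound 4 (0.34 log units; beyond the scatter) and an at least 2.2-fold lower number from compound 1 to compound 4 (0.34 log units; beyond the scatter). Those two sizes are only floors, because compound 1 and compound 2 each give a limit rather than a number: the limit of > 10000 nM in this assay, at which 2 of the 4 values shown sit.

Still open, as far as these compounds go, is how an amine, a methoxy group or a trifluoromethyl group on this same carbon would compare with bromo. The compounds shown also leave open whether a change elsewhere on the shared core would lower the number further.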